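A Trifluoromethyl Substituent Next in Line for Testing

The source may hold more compounds than are shown below. What is called first, only, known or untested is meant among the compounds shown, and "the series" means these compounds.

The three measured compounds share one core and differ at the outer ring. Compound 1 `CN(C)c1ccc(C(=O)Nc2cccc(NC(=O)COc3ccc4c(c3)CCC(=O)N4)c2)cc1` gives in an assay on isolated protein for inhibition of Rho-associated protein kinase 1 (Homo sapiens), read by scintillation counting, radiometric assay and 33P incorporation, with a stated time of 40 min, in the presence of a further agent that is not named here (a lower number here means a stronger inhibitor, a higher number a weaker inhibitor), a value of > 10000 nM, which is a limit of the assay and not a number. Compound 2 `CN(C)c1ccc(C(=O)Nc2cccc(NC(=O)COc3ccc4c(c3)OCCO4)c2)cc1` likewise returns > 10000 nM in this assay, again a limit. The step between them, a step that the two limits leave unreadable from compound 1 to compound 2, cannot be sized because the limit of > 10000 nM in this assay, at which 2 of the 3 values shown sit, covers both of its ends. Going by the values given here, compound 3 `CN(C)c1ccc(C(=O)Nc2ccc(NC(=O)COc3ccc4c(=O)ccoc4c3)cc2)cc1` is the one member with a readable result: in this assay compound 3 gives 1050 nM, the only number among the three values.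

Compound 4 `CN(C)c1ccc(C(=O)Nc2ccc(NC(=O)COc3ccc4c(=O)ccoc4c3)cc2C(F)(F)F)cc1` differs from compound 3 by trifluoromethyl in place of hydrogen on an aromatic carbon, ortho to the ((4-(dimethylamino)phenyl)carbonyl)amino group. No measured step touches this place; the single step that is shown lies at the far end of the core and is itself unreadable. With nothing to lean on, no step beyond the usual scatter is expected, and the expected step of a 1.4-fold higher number from compound 3 to compound 4 (0.15 log units; within the scatter) is set accordingly small. Compound 4 is therefore estimated at 1500 nM, within a range from 400 nM to 6000 nM.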

Compound 4, half-maximal inhibitory concentration: > 10000 nM
Compound 4 was reported as a limit (the forecaster's own chance of this, stated with the estimate: 20%); at least 6.6-fold (0.82 log units) between middle value and limit.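

In this assay, trifluoromethyl in place of hydrogen on an aromatic carbon, ortho to a ((4-(dimethylamino)phenyl)carbonyl)amino group, gives an at least 9.5-fold higher number from compound 3 to compound 4 (0.97 log units; beyond the scatter). This place on the shared core is therefore not indifferent to substitution, which the earlier compounds could not show, as none of them carries a change here and their only listed step cannot be read. Only a lower bound can be given for this step, because compound 4 stands at a limit of the assay and not at a number: the limit of > 10000 nM in this assay, at which 3 of the 4 values shown sit.

The compounds shown leave open whether the loss belongs to trifluoromethyl itself or to any group at this place, for instance a methyl, a fluorine, a methoxy group, an amine or a carboxylic acid. They also leave open what trifluoromethyl would do on the other aromatic carbons of this ring, and they offer no measurement that explains the higher number seen for compound 4.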